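The source may hold more compounds than are shown below. What is called first, only, known or untested is meant among the compounds shown, and "the series" means these compounds.

Compound 1 `O=C1C(Nc2ccc(Br)cc2)=CC(=O)c2c1nc1n2[C@H]2OC[C@@H](O)[C@H]2OC1`: 2020 nM
Compound 2 `O=C1C(N2CCCCC2)=CC(=O)c2c1nc1n2[C@H]2OC[C@@H](O)[C@H]2OC1`: > 4000 nM
Compound 3 `O=C1C(Nc2ccc(C(F)(F)F)cc2)=CC(=O)c2c1nc1n2[C@H]2OC[C@@H](O)[C@H]2OC1`: not yet measured

Among the measured compounds shown here, in a functional assay on MGC-803 cells (Homo sapiens) for inhibition, read by sulforhodamine B assay (on this read-out lower numbers stand for stronger inhibition and higher numbers for weaker inhibition), compound 1 gives 2020 nM, the only actual number in this small set. Compound 2 stands at > 4000 nM, which is a limit of this assay and not a number.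

The change under consideration is trifluoromethyl in place of bromo on an aromatic carbon, para to a large group. The rest of compound 1 stays as it is.

For the measured compounds named here, only one measured step is available, an at least 1.9-fold higher number from compound 1 to compound 2 (0.29 log units; that floor lies within the scatter). It has piperidin-1-yl in place of (4-bromophenyl)amino on a double-bonded ring carbon, so it removes the whole aromatic ring and bears only indirectly on the swap at hand. Going by the values given here, no measured step changes the group on that ring alone. A step beyond the scatter is therefore not expected in this assay, and no direction can be favoured.

The expected step is a 1.0-fold lower number from compound 1 to compound 3 (0.00 log units; within the scatter). Compound 3 is estimated at 2000 nM, with an expected range from 1000 nM to 4000 nM.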

Compound 3, half-maximal inhibitory concentration: 1860 nM
The estimate for compound 3 lay 1.1-fold (0.03 log units) above the measured number, and the stated range covers the measured number.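

In this assay, among the compounds shown here, the 4-bromophenyl to 4-(trifluoromethyl)phenyl change is the first step that alters only the group on the aromatic ring while leaving the ring and its amino link in place, and it gives a 1.1-fold lower number from compound 1 to compound 3 (0.04 log units; within the scatter). At this place, on an aromatic carbon para to a large group, trifluoromethyl can therefore stand in for bromo without a step beyond the scatter, and the series now has a second actual number with which to read changes on this ring. Compound 2 remains the only compound at a limit, so its step from compound 1 still gives a floor and not a size: the limit of > 4000 nM in this assay, at which 1 of the 3 values shown sits.

Only bromo and trifluoromethyl are compared on this ring, which leaves open whether the same holds for groups of another kind there, such as a carboxylic acid, a primary amine or a methoxy group. Also open, as far as these compounds go, is what groups other than piperidin-1-yl, such as morpholin-4-yl or benzylamino, would give on the double-bonded ring carbon, and whether any group there moves the number beyond the scatter in either direction.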